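Bromo to trifluoromethoxy on the anilino ring

A few compounds are considered here, and "the series" means these few. Any claim that something is new, unique, unknown or untested is made for them only; others in the source may bear on it.

Compound 3 `O=C(C1=C(Nc2ccc(Br)cc2)C(=O)N(CCCn2ccnc2)C1c1ccc(Br)cc1)c1ccccc1` sits second highest of the three numbers in a functional assay on NCI-H1299 cells (Homo sapiens) for antiproliferative activity, read by MTT assay, with a stated time of 72 h; a higher number here means a weaker inhibitor, a lower number a stronger inhibitor; its nearest neighbour is compound 1 `CC(C)OC1=C(C(=O)c2ccccc2)C(c2ccc(Br)cc2)N(CCCn2ccnc2)C1=O`, with a 1.0-fold higher number from compound 1 to compound 3 (0.01 log units; within the scatter), and its furthest is compound 2 `NC1=C(C(=O)c2ccccc2)C(c2ccc(Br)cc2)N(CCCn2ccnc2)C1=O`, with an 8.8-fold lower number from compound 2 to compound 3 (0.94 log units; beyond the scatter). In this assay compound 3 gives 19300 nM, compound 1 gives 18900 nM and compound 2 gives 169000 nM.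

Compound 4 `O=C(C1=C(Nc2ccc(OC(F)(F)F)cc2)C(=O)N(CCCn2ccnc2)C1c1ccc(Br)cc1)c1ccccc1` differs from compound 3 only at one aromatic carbon: trifluoromethoxy in place of bromo on an aromatic carbon. For the measured compounds named here, the only steps measured so far touch the linker from the shared core, not the substituent on the anilino ring: replacing isopropoxy by amino, an 8.9-fold higher number from compound 1 to compound 2 (0.95 log units; beyond the scatter), and replacing isopropoxy by (4-bromophenyl)amino, a 1.0-fold higher number from compound 1 to compound 3 (0.01 log units; within the scatter). Going by the values given here, neither of these tests a swap of bromo for trifluoromethoxy, so no measured step bears directly on the change to compound 4. With the exchange of one substituent for another of similar size on a ring whose presence itself made the difference in an 8.8-fold lower number from compound 2 to compound 3 (0.94 log units; beyond the scatter), no step beyond the scatter is expected in this assay.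

Compound 4 is therefore expected near 19000 nM, within 8000 nM to 45000 nM, which would amount to an estimated step of a 1.0-fold lower number from compound 3 to compound 4 (0.01 log units; within the scatter).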

Compound 4, half-maximal inhibitory concentration: 11500 nM
Beside the measured number, compound 4's estimate is 1.7-fold (0.22 log units) above it; measured number inside the range.
By their numbers in this assay, from the lowest: compounds 4, 1 and 3 (each within the scatter of the next); then compound 2.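

The bromo on the anilino ring, para to a large group, can give way to trifluoromethoxy, with five heavy atoms in place of one and a hydrogen-bond acceptor added, and this assay still shows only a 1.7-fold lower number from compound 3 to compound 4 (0.22 log units; within the scatter). The large gain over the free amine also holds with this second aryl group: a 15-fold lower number from compound 2 to compound 4 (1.17 log units; beyond the scatter), a step of the same direction as the one seen with 4-bromophenyl, while a 1.6-fold lower number from compound 1 to compound 4 (0.22 log units; within the scatter) leaves the anilino compound level with the isopropoxy compound, so the earlier match between these two substituents does not depend on the bromo. No measurement at hand accounts for the tolerance of this position or for the gap to the free amine.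

Only two substituents at this one ring carbon are shown, and both leave the number within the scatter of each other, so the part played by the substituent itself remains unsettled. An unsubstituted phenyl, a methoxy, a carboxylic acid or an amine at that carbon would show whether the aryl ring alone carries the gain or whether the group on it can move the number in either direction.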